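A few compounds are considered here, and "the series" means these few. Any claim that something is new, unique, unknown or untested is made for them only; others in the source may bear on it.

Measured so far:
compound 1 `CC[C@H](C)[C@H](N)CN(C(=O)[C@@H]1C[C@H]1c1ccc(Cl)cc1)c1ccc(-c2ccccc2)cc1`, in a functional assay for agonist activity at G protein-coupled receptor 88 (Homo sapiens), read by HTRF and cAMP accumulation; a higher number here means that more compound is needed for the effect, a lower number that less compound is needed: 4300 nM
compound 2 `CCc1ccc(-c2ccc(N(C[C@@H](N)[C@@H](C)CC)C(=O)[C@@H]3C[C@H]3c3ccccc3)cc2)cc1`, in this assay: 44 nM

Among the measured compounds shown here, compound 2 holds the lower of the two numbers in this assay; its only neighbour is compound 1, and the gap between them lies beyond the scatter. Compound 3 `CCOC(=O)c1ccc(-c2ccc(N(C[C@@H](N)[C@@H](C)CC)C(=O)[C@@H]3C[C@H]3c3ccccc3)cc2)cc1` has not yet been measured. It differs from compound 2 in one place: ethoxycarbonyl in place of ethyl on an aromatic carbon. For the measured compounds named here, no step between measured compounds covers this change, so the expectation rests on compound 2 alone. Compound 3 is expected to give a somewhat higher number, a step of a 3.4-fold higher number from compound 2 to compound 3 (0.53 log units; beyond the scatter) in this assay. The estimated value of compound 3 is 150 nM, with a range from 40 nM to 600 nM.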

Compound 3, half-maximal effective concentration: 260 nM
Estimate against measurement, compound 3: 1.7-fold (0.24 log units) below; the range from low to high includes it.
By their numbers in this assay, from the lowest: compound 2; then compound 3; then compound 1.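

In this assay, replacing 4-ethylphenyl with 4-(ethoxycarbonyl)phenyl gives a 5.9-fold higher number from compound 2 to compound 3 (0.77 log units; beyond the scatter), the first step read at this position. The step is modest but beyond the scatter, so the number responds to this change while the compound keeps measurable agonist activity. It shows that ethoxycarbonyl, a larger group carrying hydrogen-bond acceptors, is accepted here, though at a cost relative to ethyl.

Nothing measured here explains the step. As far as these compounds go, whether a carboxylic acid, an amine or a longer alkyl chain at this position would give a lower or higher number remains open.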